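Alkyl groups on the ring nitrogen and thromboxane synthase inhibition

A few compounds are considered here, and "the series" means these few. Any claim that something is new, unique, unknown or untested is made for them only; others in the source may bear on it.

Compound 1 `Cn1nc(-c2cccnc2)c2ccccc2c1=O`: 63%
Compound 2 `CCn1nc(-c2cccnc2)c2ccccc2c1=O`: 87%
Compound 3 `CCCCn1nc(-c2cccnc2)c2ccccc2c1=O`: 91%

In an assay on isolated protein (Oryctolagus cuniculus) with Thromboxane-A synthase (Homo sapiens) as the target, tested at 1 uM (on this read-out lower numbers stand for less inhibition and higher numbers for more inhibition at the one concentration tested (going by the name of the read-out)), compound 1 gives 63%, compound 2 gives 87% and compound 3 gives 91%, the highest of the three numbers. The rises were a number 24 percentage points higher from compound 1 to compound 2 (beyond the scatter) and a number 28 percentage points higher from compound 1 to compound 3 (beyond the scatter), while a number 4 percentage points higher from compound 2 to compound 3 (within the scatter). Compound 4 `O=c1c2ccccc2c(-c2cccnc2)nn1C1CCCC1` carries cyclopentyl in place of butyl on an aromatic nitrogen. Among the compounds with values here, no measured step exchanges one chain for a ring of this kind; the steps only show that lengthening the chain beyond ethyl brought nothing beyond the scatter. The author therefore expects no step beyond the scatter, a number 2 percentage points lower from compound 3 to compound 4 (within the scatter). Compound 4 is estimated at 89%, with a range from 76% to 97%.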

Compound 4, a percentage reported as inhibition, at one concentration (the size of the read-out at that concentration, not a potency): 97%
The estimate for compound 4 lay 8 percentage points below the measured number, within the range that was stated.
By their numbers in this assay, from the lowest: compound 1; then compounds 2, 3 and 4 (each within the scatter of the next).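

In this assay a ring can take the place of an open chain on the aromatic nitrogen: cyclopentyl in place of butyl gives a number 6 percentage points higher from compound 3 to compound 4 (within the scatter) and cyclopentyl in place of ethyl gives a number 10 percentage points higher from compound 2 to compound 4 (within the scatter), so neither exchange separates the compounds. Only the exchange for methyl, with a number 34 percentage points higher from compound 1 to compound 4 (beyond the scatter), stands out from the scatter, which leaves the methyl group alone apart. Nothing available explains this result.

From the compounds shown here alone, whether cyclopropyl, cyclohexyl or a branched isopropyl group would read the same remains open. The single test concentration also leaves any order among compound 2, compound 3 and compound 4 unsettled.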